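The source may hold more compounds than are shown below. What is called first, only, known or untested is meant among the compounds shown, and "the series" means these compounds.

Compound 1 `O=C(CCCCC(S)CCS)Nc1ccc(F)cc1`: 6.84%
Compound 2 `CC(=O)SCCC(CCCCC(=O)Nc1ccccc1)SC(C)=O`: 13.1%

In a functional assay on NCI-H460 cells (Homo sapiens) for inhibition, read by MTT assay, with a stated time of 24 h, tested at 1 ug/mL (a lower number here means less inhibition of growth, a higher number more inhibition of growth at the concentration tested), compound 2 gives 13.1%, and compound 1 gives 6.84%. These two numbers lie within the usual scatter of each other, so they cannot be ranked, and compound 2 stands level with compound 1.

Compound 3 `CC(=O)SCCC(CCCCC(=O)Nc1ccc(Cl)cc1)SC(C)=O` keeps the structure of compound 2 except in one place: chloro in place of hydrogen on an aromatic carbon. This puts chloro in place of hydrogen on an aromatic carbon, para to a large group, turning phenyl into 4-chlorophenyl. Among the compounds with values here, no pair of measured compounds differs in just one place, so the data show no direct precedent for this change. With only compound 2 at 13.1% as a guide, no step beyond the scatter is expected in this assay. The expected a number 1.9 percentage points higher from compound 2 to compound 3 (within the scatter) is small. For compound 3 the estimated value is 15%, with an expected range of 4% to 30%.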

Compound 3, percent growth inhibition at one concentration: 15.4%
The estimate for compound 3 lay 0.4 percentage points below the measured number, within the range that was stated.
By their numbers in this assay, from the lowest: compounds 1, 2 and 3 (each within the scatter of the next).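

Within the data shown here, this is the first pair that differs in only one place, so it gives the first direct reading of a change on the aromatic ring. In this assay, among these compounds, putting chloro in place of hydrogen para to a large group, which turns phenyl into 4-chlorophenyl, gives a number 2.3 percentage points higher from compound 2 to compound 3 (within the scatter), so this change at this position shows no step that can be told apart from the usual scatter of such measurements. Nothing measured here bears on the reason for this result.

Going by these compounds, whether a methoxy group or a nitrile in place of the chloro would give a step beyond the scatter remains open. Also open, on these data alone, is whether a longer chain in place of the present one would move the number, or whether a different concentration would separate compound 2 and compound 3.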